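Same Halogen Swap, Longer Chain: Expected Result for Compound 4

The compounds below may be only part of what the source reports. "The series", "measured", "known", "first", "only" and "open" are said of these compounds alone.

Measured so far:
Compound 1, `O=C(CCCCC1CCSS1)NCc1cn(CCCOc2ccc3cc(-c4ccc(Br)cc4)c(=O)oc3c2)nn1`: 42.8%
Compound 2, `O=C(CCCCC1CCSS1)NCc1cn(CCCOc2ccc3cc(-c4ccc(Cl)c(Cl)c4)c(=O)oc3c2)nn1`: 42.4%
Compound 3, `O=C(CCCCC1CCSS1)NCc1cn(CCCCCOc2ccc3cc(-c4ccc(Br)cc4)c(=O)oc3c2)nn1`: 43.7%

In a functional assay on PC-12 cells (Rattus norvegicus) for cytotoxicity, read by MTT assay, with stated times of 3 h and 2 h, tested at 1 uM (a lower number here means a weaker effect, a higher number a stronger effect of the compound at the concentration tested), compound 1 gives 42.8% and compound 2 gives 42.4%. The two differ in one place, (3,4-dichlorophenyl in place of 4-bromophenyl on an aromatic carbon), and the step of a number 0.4 percentage points lower from compound 1 to compound 2 (within the scatter) is within the scatter. Compound 3 gives 43.7% in this assay; its values relative to compound 1 and compound 2 also lie within the scatter, so no order among the three can be read. The difference between the core of compound 3 and the core of compound 1 is not broken down here.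

Compound 4, `O=C(CCCCC1CCSS1)NCc1cn(CCCCCOc2ccc3cc(-c4ccc(Cl)c(Cl)c4)c(=O)oc3c2)nn1`, has not yet been measured in this assay. It relates to compound 3 as compound 2 relates to compound 1: 3,4-dichlorophenyl in place of 4-bromophenyl on an aromatic carbon. The place lines of the two changes agree word for word, so this is the same change made on a different core. The step from compound 3 to compound 4 is expected to be a number 0.4 percentage points lower from compound 3 to compound 4 (within the scatter), resting on the step of a number 0.4 percentage points lower from compound 1 to compound 2 (within the scatter) in this assay. Compound 4 is therefore estimated at 43.3%, with a range from 35% to 51%.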

Compound 4, a percentage reported as activity, at one concentration (the size of the read-out at that concentration, not a potency): 50.6%
For compound 4 the middle estimate is 7.3 percentage points below the measured one, and the stated range covers the measured number.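

In this assay, 3,4-dichlorophenyl in place of 4-bromophenyl on the core of compound 3 gives a number 6.9 percentage points higher from compound 3 to compound 4 (within the scatter). Set beside the same change on the core of compound 1, the two steps cannot be told apart: the same change on two cores in this assay, a number 0.4 percentage points lower (within the scatter) from compound 1 to compound 2 and a number 6.9 percentage points higher (within the scatter) from compound 3 to compound 4, 7.3 percentage points apart, within the scatter of two such steps. For the compounds shown here, this shows that, across these two cores, the change carries over with no difference that can be separated from the usual scatter; it does not show that the change has any real effect on either core, nor that it would read the same way on any other core, since the comparison rests on only two pairs.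

The compounds shown leave open how this assay would read with an unsubstituted phenyl or a phenyl bearing a methoxy group or an amine in the same place. Going by these compounds alone, they also leave open what a longer chain than the one in compound 3 and compound 4 would do to the values.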